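A few compounds are considered here, and "the series" means these few. Any claim that something is new, unique, unknown or untested is made for them only; others in the source may bear on it.

Measured compounds:
compound 1 `COc1ccc(C2=NN(C(=O)NS(=O)(=O)c3ccc(C)cc3)CC2c2ccccc2)c(OC)c1` — 7.21%
compound 2 `COc1ccc(C2=NN(C(=S)NC(=O)c3ccc(Cl)cc3)CC2C)c(OC)c1` — 1.43%
compound 3 `CCOC(=O)C(=O)C(C(=O)c1ccc(OC)cc1OC)c1ccccc1` — 21.2%

In a functional assay on the whole organism (strain albino) for inhibition, with Rattus norvegicus as the target, read by paw edema, with stated times of 30 min and 4 h, at a dose of 25 mg/kg by the intraperitoneal route (a lower number here means less inhibition, a higher number more inhibition at the dose given (going by the name of the read-out)), compound 3 gives the highest of the three numbers; the nearest, compound 1, lies lower, and compound 2 lies furthest below it, both gaps beyond the usual scatter. The unmeasured compound 4 `CCOC(=O)C(=O)C(C)C(=O)c1ccc(OC)cc1OC` differs from compound 3 by a single change: methyl in place of phenyl on a saturated chain carbon bound to two carbonyl carbons. No step between measured compounds in this series isolates such a change, so nothing shown here sets its direction. The author expects a modest downward step, estimated as a number 6.2 percentage points lower from compound 3 to compound 4 (within the scatter), a size that may fall within the scatter. For compound 4 the estimated value is 15%, with a range from 3% to 28%.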

Compound 4, a percentage reported as inhibition, in the whole organism at one dose (the size of the read-out at that dose, not a potency): 24.6%
Compound 4: middle estimate off by 9.6 percentage points, on the low side; the range from low to high includes it.
By their numbers in this assay, from the lowest: compounds 2 and 1 (each within the scatter of the next); then compounds 3 and 4 (each within the scatter of the next).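

In this assay, within the data shown here, the step of a number 3.4 percentage points higher from compound 3 to compound 4 (within the scatter) gives the first reading at this position, the saturated chain carbon bound to two carbonyl carbons. Methyl in place of phenyl stays within the usual scatter, so the six-membered aromatic ring is not required here for the inhibition seen at the dose given. Nothing shown accounts for this result. The compounds shown leave open whether a longer chain or an amine on this carbon would give a similar number. They also leave open whether a carboxylic acid in place of the ethyl ester would do so.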